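The source may hold more compounds than are shown below. What is called first, only, known or untested is meant among the compounds shown, and "the series" means these compounds.

Compound 1, `Cc1ccccc1Nc1nc(Nc2ccc(N3CCNCC3)cn2)ncc1Cl`: 3410 nM
Compound 2, `Cc1ccccc1Nc1nc(Nc2ccc(N3CCCCC3)cn2)ncc1Cl`: 21400 nM
Compound 3, `CN1CCN(c2ccc(Nc3ncc(Cl)c(Nc4ccccc4)n3)nc2)CC1`: 51800 nM

All three numbers come from a functional assay on MCF7 cells (Homo sapiens) for inhibition, read by CCK-8 assay, with a stated time of 48 h; a higher number here means a weaker inhibitor of growth, a lower number a stronger inhibitor of growth. Compound 3 stands highest of the three: its number lies above that of compound 2 and further still above that of compound 1, and both of those gaps are wider than the scatter of repeated measurements, so compound 3 is the weakest growth inhibitor among the measured compounds.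

Compound 4, `COc1ccc(Nc2nc(Nc3ccc(N4CCN(C)CC4)cn3)ncc2Cl)cc1`, differs from compound 3 in one place only: methoxy in place of hydrogen on an aromatic carbon. The only measured step among these compounds is a different change at a different place, a 6.3-fold higher number from compound 1 to compound 2 (0.80 log units; beyond the scatter), where piperidin-1-yl replaced piperazin-1-yl. Among the compounds with values here, that step says nothing about adding a methoxy group to the anilino ring, so there is no measured precedent for the change from compound 3 to compound 4. Without one, the expectation is a step of about a 1.2-fold lower number from compound 3 to compound 4 (0.06 log units; within the scatter), which is within the scatter, so compound 4 is expected to behave much like compound 3 in this assay. The estimate for compound 4 is 45000 nM, with a range from 15000 nM to 135000 nM.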

Compound 4, concentration for 50% growth inhibition: 8450 nM
Compound 4: the middle estimate sits 5.3-fold (0.73 log units) above what was measured; measured number below the stated range.
By their numbers in this assay, from the lowest: compound 1; then compound 4; then compound 2; then compound 3.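

Before this result, the only measured step concerned the piperazin-1-yl group, so nothing showed whether the anilino ring of the shared core responds to change. In this assay, methoxy in place of hydrogen on that ring, para to a large group, gives a 6.1-fold lower number from compound 3 to compound 4 (0.79 log units; beyond the scatter), which shows that this position is not a silent one and that a group of two heavy atoms placed there can strengthen growth inhibition by a step beyond the scatter. No measurement in hand accounts for this gain, and a single pair of compounds cannot show how general it is.

Going by these compounds, whether a hydroxyl group, a fluorine atom or a longer chain such as ethoxy at the same place would lower the number further, or raise it again, stays open. It is also unclear whether methoxy would bring a similar step alongside the other groups seen in this set, such as the unmethylated piperazin-1-yl group of compound 1, whose anilino ring also carries a methyl group.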